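Series notes: replacing the dimethoxyphenyl of compound 2

This account rests on a few compounds, and the source may have more. Where it says the series, first, only, none or still open, it means among the compounds named here.

Of the compounds shown here, three of the shared core have been measured in a functional assay on U-87MG ATCC cells for antiproliferative activity against U-87 MG (Homo sapiens), read by MTT assay, with a stated time of 48 h, tested at 5 uM; on this read-out lower numbers stand for a stronger effect and higher numbers for a weaker effect at the one concentration tested. Compound 1 `COc1ccc(-c2nc(SCC(=O)c3sc(-c4ccccc4)nc3C)[nH]c(=O)c2C#N)cc1` gives 97.3%. Compound 2 `COc1ccc(-c2nc(SCC(=O)c3sc(-c4ccccc4)nc3C)[nH]c(=O)c2C#N)cc1OC` gives 80.8%, the lowest of the three numbers and the strongest effect seen so far, with both other compounds beyond the scatter above it. Compound 3 `COc1ccc(-c2nc(SCC(=O)c3sc(-c4ccc(Cl)cc4)nc3C)[nH]c(=O)c2C#N)cc1OC` gives 93.4%. The step of a number 16.5 percentage points lower from compound 1 to compound 2 (beyond the scatter) goes with methoxy in place of hydrogen on an aromatic carbon; the step of a number 12.6 percentage points higher from compound 2 to compound 3 (beyond the scatter) goes with chloro in place of hydrogen on an aromatic carbon.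

Compound 4 `Cc1nc(-c2ccccc2)sc1C(=O)CSc1nc(-c2cccc(Cl)c2)c(C#N)c(=O)[nH]1` is not yet measured. Against compound 2 the change is 3-chlorophenyl in place of 3,4-dimethoxyphenyl on an aromatic carbon, the site being ortho to a cyano group and next to the ring nitrogen. Among the measured compounds shown here, two measured steps bear on it, neither exactly. Stripping away the methoxy groups runs opposite to a number 16.5 percentage points lower from compound 1 to compound 2 (beyond the scatter) and points toward a higher number; adding a chloro, as in a number 12.6 percentage points higher from compound 2 to compound 3 (beyond the scatter), also went higher, though on a different ring. A modest rise is therefore expected in this assay, of the order of the measured steps, rather than none. For compound 4 the estimate is 92%, within 80% to 100%, meaning an expected step of a number 11.2 percentage points higher from compound 2 to compound 4 (beyond the scatter).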

Compound 4, a percentage reported as activity, at one concentration (the size of the read-out at that concentration, not a potency): 86.9%
The estimate for compound 4 lay 5.1 percentage points above the measured number; the range from low to high includes it.
By their numbers in this assay, from the lowest: compounds 2, 4, 3 and 1 (each within the scatter of the next, the first and the last beyond it).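

At this position, the aromatic carbon ortho to a cyano group, 3-chlorophenyl in place of 3,4-dimethoxyphenyl gives a number 6.1 percentage points higher from compound 2 to compound 4 (within the scatter) in this assay, so the two methoxy groups are not needed to keep the read-out of compound 2 at this site. The step of a number 10.4 percentage points lower from compound 1 to compound 4 (beyond the scatter) with 3-chlorophenyl in place of 4-methoxyphenyl shows that the separation from compound 1 is not confined to the 3,4-dimethoxyphenyl group and can also be reached with an aryl group that carries no oxygen. No measurement at hand accounts for either step.

Open, from the compounds shown here alone, is whether the chloro of 3-chlorophenyl contributes anything here, or whether a plain phenyl at the same site would give the same read-out. Equally open, going by these compounds, is how an amine or a carboxylic acid on this ring would read, and whether any group at this position can take the number well below the narrow range of these four compounds at the one concentration tested.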